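This account rests on a few compounds, and the source may have more. Where it says the series, first, only, none or still open, it means among the compounds named here.

Working notes on the series. For compound 1 (`C[C@]1(CN2CCc3nc(N4CCCCC4)ccc3C2)Cn2cc([N+](=O)[O-])nc2O1`), an ADME assay on Vero cells (Chlorocebus sabaeus) for cytotoxicity, read by MTT assay, with a stated time of 72 h (a higher number here means that more compound is tolerated, a lower number that less compound is tolerated), holds the entry "not determined" (no result reported) and adds nothing to the reading. Compound 2 (`C[C@]1(CN2CCc3nc(-c4cccc(F)c4F)ccc3C2)Cn2cc([N+](=O)[O-])nc2O1`) gives > 32 ug/mL as a limit of the assay. Compound 3 (`C[C@]1(CN2CCc3nc(-c4cccc(Cl)c4F)ccc3C2)Cn2cc([N+](=O)[O-])nc2O1`) gives > 32 ug/mL as a limit too, so it has no exact position. What the series shows so far is the limit of > 32 ug/mL in this assay, at which 2 of the 3 values shown sit, and no exact value.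

Compound 4 (`C[C@]1(CN2CCc3nc(-c4cc(Cl)ccc4F)ccc3C2)Cn2cc([N+](=O)[O-])nc2O1`) has 5-chloro-2-fluorophenyl in place of 3-chloro-2-fluorophenyl on an aromatic carbon, with the same atoms joined differently: 5-chloro-2-fluorophenyl in place of 3-chloro-2-fluorophenyl on an aromatic carbon is the whole change.

Among the measured compounds shown here, the only measured step that bears on this is a step that the two limits leave unreadable from compound 2 to compound 3 with chloro in place of fluoro on an aromatic carbon, and it offers no size to carry over. No step beyond the scatter is therefore expected in this assay and no direction is favoured. The expected change is a step that the limit leaves unreadable from compound 3 to compound 4 as an estimate only. Compound 4 is estimated at 40 ug/mL with an expected range of 20 ug/mL to 80 ug/mL and another limit is the likely report.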

Compound 4, half-maximal cytotoxic concentration: > 32 ug/mL
Compound 4: only a limit was reported; the forecaster's own chance of this, stated with the estimate: 85%; the middle value is on the limit's open side.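

No new step can be read in this assay from compound 2 or compound 3 to compound 4, as all three compounds sit at a limit: the limit of > 32 ug/mL in this assay, at which 3 of the 4 values shown sit.

The compounds shown leave open where the exact values of compound 2, compound 3 and compound 4 lie and whether these values differ.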